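A few compounds are considered here, and "the series" means these few. Any claim that something is new, unique, unknown or untested is made for them only; others in the source may bear on it.

Compound 1 `O=C(Nc1ccccc1C(F)(F)F)c1cc(Cl)ccc1O` was tested in an ADME assay on cells (Macrophage, Mus musculus) for cytotoxicity, read by resazurin assay, with a stated time of 3 days (a lower number here means a stronger inhibitor, a higher number a weaker inhibitor), where compound 1 gives 19000 nM. Compound 2 `O=C(Nc1cc(Br)ccc1C(F)(F)F)c1cc(Cl)ccc1O` differs from it by bromo in place of hydrogen on an aromatic carbon and gives 5800 nM, a step of a 3.3-fold lower number from compound 1 to compound 2 (0.52 log units; beyond the scatter). Compound 3 `O=C(Nc1cc(F)cc(F)c1)c1cc(Cl)ccc1O` rests on a different core; how the cores of compound 3 and compound 1 differ is not broken down here. In this assay compound 3 gives 6100 nM, which lies within the scatter of compound 2 and beyond it from compound 1. Compound 4 `O=C(Nc1cc(F)c(Br)c(F)c1)c1cc(Cl)ccc1O` is not yet measured and differs from compound 3 by bromo in place of hydrogen on an aromatic carbon. This is the same kind of change as that from compound 1 to compound 2, though the place differs: there the bromo sits meta to a large group and para to a trifluoromethyl group, here ortho to two fluoro groups and para to a large group. Because a 3.3-fold lower number from compound 1 to compound 2 (0.52 log units; beyond the scatter) lowered the number, a comparable step is expected for compound 4, estimated as a 2.4-fold lower number from compound 3 to compound 4 (0.39 log units; beyond the scatter). Compound 4 is therefore expected to give about 2500 nM, between 1000 nM and 7000 nM.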

Compound 4, half-maximal inhibitory concentration: 4300 nM
Beside the measured number, compound 4's estimate is 1.7-fold (0.24 log units) below it; the range from low to high includes it.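

On the core of compound 3, bromo in place of hydrogen on an aromatic carbon amounts in this assay to a 1.4-fold lower number from compound 3 to compound 4 (0.15 log units; within the scatter), so on this core the change cannot be told apart from repeat measurement. Set beside the earlier step, the two cannot be separated either: the same change on two cores in this assay, a 3.3-fold lower number (0.52 log units; beyond the scatter) from compound 1 to compound 2 and a 1.4-fold lower number (0.15 log units; within the scatter) from compound 3 to compound 4, 2.3-fold (0.36 log units) apart, within the scatter of two such steps. Within the data shown here, the two pairs are thus compatible with the change carrying over between cores, but they do not show that it does, since only one of the two steps lies beyond the scatter and the bromo sits in a different place on each core.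

The compounds shown leave open whether the step depends on the core or on the place of the bromo. They also leave open how an amine or a carboxylic acid in that same place would read in this assay.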